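Shortening the chain of compound 1 and losing its nitrile

This account rests on a few compounds, and the source may have more. Where it says the series, first, only, none or still open, it means among the compounds named here.

In an assay on isolated protein for binding affinity to leukotriene B4 receptor 1 (Homo sapiens), tested at 1 uM (a higher number here means more inhibition at the concentration tested (going by the name of the read-out), a lower number less inhibition), compound 1 `C=CCc1cc(C(C)=O)c(O)cc1OCCCCCC#N` gives 41%, the second highest of three numbers; it lies above compound 2 and below compound 3. Compound 2 `CCc1cc(C(C)=O)c(O)cc1OCCCCCCCC(C)(C)C#N` gives 29% and compound 3 `CCc1cc(C(C)=O)c(O)cc1OCCCCCC(C)(C)c1nnn(C)n1` gives 66%. Compound 4 `C=CCc1cc(C(C)=O)c(O)cc1OCCCC` differs from compound 1 by hydrogen in place of cyanomethyl on a saturated chain carbon, four bonds along the chain from an oxygen on an aromatic ring. Among the measured compounds shown here, the one measured step that alters the group carried on the chain is a number 37 percentage points higher from compound 2 to compound 3 (beyond the scatter), and it is large, showing that this assay answers strongly to what the chain carries. Compound 4 carries nothing there, so a downward step is expected, namely a number 17 percentage points lower from compound 1 to compound 4 (beyond the scatter). Compound 4 is therefore estimated to give 24%, with a range from 5% to 43%.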

Compound 4, a percentage reported as inhibition, at one concentration (the size of the read-out at that concentration, not a potency): 8%
Compound 4: middle estimate off by 16 percentage points, on the high side; the measured number falls inside the stated range.
By their numbers in this assay, from the lowest: compound 4; then compound 2; then compound 1; then compound 3.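

Replacing cyanomethyl with hydrogen at this position gives a number 33 percentage points lower from compound 1 to compound 4 (beyond the scatter) in this assay, so here the chain is not merely exchanging one end group for another, as in the earlier step, but losing both length and its nitrile, and the reading falls well beyond the scatter. Nothing measured explains this fall.

The step leaves open how much of the loss belongs to the nitrile and how much to the shorter chain. A carboxylic acid or an amine at the end of the chain of compound 1 would bear on that question.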